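The source may hold more compounds than are shown below. What is called first, only, known or untested is meant among the compounds shown, and "the series" means these compounds.

Measured compounds in the series:

Compound 1 `C/C=C/C(=O)Nc1cccc(Oc2nc(Nc3cccc(OC)c3)nc3c2CSCC3)c1` gives 13800 nM in a functional assay on HeLa cells (Homo sapiens) for antiproliferative activity, read by MTT assay, with a stated time of 72 h; on this read-out higher numbers stand for weaker inhibition and lower numbers for stronger inhibition.
Compound 2 `CC/C=C/C(=O)Nc1cccc(Oc2nc(Nc3cccc(OC)c3)nc3c2CSCC3)c1` gives 27200 nM in this assay.
Compound 3 `C/C=C/C(=O)Nc1cccc(Oc2nc(Nc3ccc(OC)nc3)nc3c2CSCC3)c1` gives 16500 nM in this assay.

Compound 4 `CC/C=C/C(=O)Nc1cccc(Oc2nc(Nc3ccc(OC)nc3)nc3c2CSCC3)c1` is not yet measured in this assay. Compound 4 stands to compound 3 as compound 2 stands to compound 1: the change is methyl in place of hydrogen on a saturated chain carbon bound to a double-bonded chain carbon, and the same kind of change, (methyl in place of hydrogen on a saturated chain carbon bound to a double-bonded chain carbon), has already been made once, where it gave a 2.0-fold higher number from compound 1 to compound 2 (0.29 log units; within the scatter). The two place lines read the same word for word, so nothing around the place differs. The two cores differ by 6-methoxypyridin-3-yl in place of 3-methoxyphenyl on a nitrogen on an aromatic ring, and that difference gave a 1.2-fold higher number from compound 1 to compound 3 (0.08 log units; within the scatter). Compound 3 sits near compound 1 and compound 2 in this assay; none of the three values is separated from the others beyond the scatter.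

The expectation for compound 4 therefore rests on the step from compound 1 to compound 2, which was a 2.0-fold higher number from compound 1 to compound 2 (0.29 log units; within the scatter). A step of similar size is expected from compound 3 to compound 4, namely a 1.7-fold higher number from compound 3 to compound 4 (0.23 log units; within the scatter), and it is expected to stay within the scatter. Compound 4 is estimated at 28000 nM in this assay, expected between 12000 nM and 60000 nM.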

Compound 4, half-maximal inhibitory concentration: 31200 nM
Compound 4: the middle estimate sits 1.1-fold (0.05 log units) below what was measured; low and high end bracket the measured number.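

In this assay, methyl in place of hydrogen on a saturated chain carbon bound to a double-bonded chain carbon gave a 1.9-fold higher number from compound 3 to compound 4 (0.28 log units; within the scatter), and it reads the same on both cores: the same change on two cores in this assay, a 2.0-fold higher number (0.29 log units; within the scatter) from compound 1 to compound 2 and a 1.9-fold higher number (0.28 log units; within the scatter) from compound 3 to compound 4, 1.0-fold (0.02 log units) apart, within the scatter of two such steps
The exchange of 3-methoxyphenyl for 6-methoxypyridin-3-yl, now read with but-1-en-1-yl in place of prop-1-en-1-yl, gave a 1.1-fold higher number from compound 2 to compound 4 (0.06 log units; within the scatter), and it too reads the same in both settings: the same change on two cores in this assay, a 1.2-fold higher number (0.08 log units; within the scatter) from compound 1 to compound 3 and a 1.1-fold higher number (0.06 log units; within the scatter) from compound 2 to compound 4, 1.0-fold (0.02 log units) apart, within the scatter of two such steps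
The two changes therefore carry from one core to the other here without a detectable difference, but each step lies within the scatter, so this does not show that either change has a real effect on the number, and two cores give no basis for a rule across the series.

The compounds shown leave open how a longer chain than but-1-en-1-yl, or an amine on that chain, would read in this assay. They also leave open whether the two changes would still add up alike if one of them gave a step beyond the scatter.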